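Compound 4: Hydrogen in Place of Fluoro

A few compounds are considered here, and "the series" means these few. Any claim that something is new, unique, unknown or untested is made for them only; others in the source may bear on it.

Of the compounds shown here, three with a shared core have been measured in an in vitro functional assay on HEK293 cells for antagonist activity at melanin-concentrating hormone receptor 1 (Homo sapiens); a higher number here means a larger maximal response, a lower number a smaller maximal response. Compound 1 `CC(=O)OCC(C)(C)NC(=O)N(CCC1CCN(Cc2ccc(C)cc2)CC1)Cc1ccc(-c2ccccc2)cc1` gives 102% in this assay. Compound 2 `Cc1ccc(CN2CCC(CCN(Cc3ccc(-c4ccccc4)cc3)C(=O)NC(C)(C)CO)CC2)cc1` gives 105%, and the step of a number 3 percentage points higher from compound 1 to compound 2 (within the scatter) shows how little that change moved the maximal response. Compound 3 `CCC(CO)(CO)NC(=O)N(CCC1CCN(Cc2ccc(C)cc2)CC1)Cc1ccc(-c2ccc(F)cc2)cc1` gives 111% in this assay; its gaps to compound 2 and to compound 1 both lie within the usual scatter, so the three numbers cannot be told apart.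

Compound 4 `CCC(CO)(CO)NC(=O)N(CCC1CCN(Cc2ccc(C)cc2)CC1)Cc1ccc(-c2ccccc2)cc1` differs from compound 3 in one place: hydrogen in place of fluoro on an aromatic carbon. Among the measured compounds shown here, no measured step touches this change; the only step known, a number 3 percentage points higher from compound 1 to compound 2 (within the scatter), concerns the acetyl on an oxygen on a saturated carbon and stayed within the scatter. With the three measured compounds all reaching about the same maximal response, compound 4 is expected to show a step of a number 6 percentage points lower from compound 3 to compound 4 (within the scatter), nothing beyond the scatter. Compound 4 is therefore estimated at 105% in this assay, with a range from 95% to 115%.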

Compound 4, largest response reached (reported as Imax), in percent of the reference or control that the assay uses: 93.5%
Compound 4: the middle estimate sits 11.5 percentage points above what was measured, outside the stated range (below it).
By their numbers in this assay, from the lowest: compounds 4, 1, 2 and 3 (each within the scatter of the next, the first and the last beyond it).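

In this assay the change from 4-fluorophenyl to phenyl leaves the maximal response a number 17.5 percentage points lower from compound 3 to compound 4 (beyond the scatter) and so shows that a single atom on this aromatic carbon, para to a large group, can matter, which the earlier step did not reveal. On the amide-type nitrogen, 1,1-bis(hydroxymethyl)propyl in place of 1-(hydroxymethyl)-1-methylethyl gives a number 11.5 percentage points lower from compound 2 to compound 4 (beyond the scatter) while the same group in place of 1-(acetoxymethyl)-1-methylethyl gives a number 8.5 percentage points lower from compound 1 to compound 4 (within the scatter) and so the reading at that position depends on the group replaced. Nothing available explains these differences.

As far as these compounds go, whether chloro or methyl on this aromatic carbon would behave like fluoro stays open. So does whether swapping hydrogen for fluoro has a similar effect alongside the amide-nitrogen groups of compound 1 and compound 2.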